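This account rests on a few compounds, and the source may have more. Where it says the series, first, only, none or still open, it means among the compounds named here.

Measured compounds in a functional assay on cells (Melanoma cell, Homo sapiens) for cytotoxicity, read by sulforhodamine B assay, with a stated time of 48 h; a higher number here means a weaker inhibitor of growth, a lower number a stronger inhibitor of growth:
Compound 1 `COc1ccc(C2CC(c3ccccc3)=NN2C2=NC(=O)/C(=C3\C(=O)Nc4ccccc43)S2)cc1` gives 2000 nM.
Compound 2 `COc1ccc(C2CC(c3ccc4ccccc4c3)=NN2C2=NC(=O)/C(=C3\C(=O)Nc4ccccc43)S2)cc1` gives 4800 nM.
Compound 3 `O=C1N=C(N2N=C(c3ccccc3)CC2c2ccc(Cl)cc2)S/C1=C1/C(=O)Nc2ccccc21` gives 280 nM.

Among these three, compound 3 has the lowest number, with a 7.1-fold lower number from compound 1 to compound 3 (0.85 log units; beyond the scatter) and compound 2 further off still. Compound 4 `O=C1N=C(N2N=C(c3ccc4ccccc4c3)CC2c2ccc(Cl)cc2)S/C1=C1/C(=O)Nc2ccccc21` differs from compound 3 in one place: naphthalen-2-yl in place of phenyl on a carbon with a double bond to nitrogen. Among the compounds with values here, the one measured step of the same kind is a 2.4-fold higher number from compound 1 to compound 2 (0.38 log units; beyond the scatter), which gives a modest shift beyond the scatter in the direction of a weaker inhibitor of growth. On that basis compound 4 is expected to show a similar modest increase, a 2.4-fold higher number from compound 3 to compound 4 (0.38 log units; beyond the scatter), in this assay. The estimate for compound 4 is therefore 670 nM, with a range from 250 nM to 1800 nM.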

Compound 4, concentration for 50% growth inhibition: 350 nM
Compound 4: the middle estimate sits 1.9-fold (0.28 log units) above what was measured; the range from low to high includes it.
By their numbers in this assay, from the lowest: compounds 3 and 4 (each within the scatter of the next); then compound 1; then compound 2.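

Naphthalen-2-yl in place of phenyl, on a carbon with a double bond to nitrogen, gives a 1.3-fold higher number from compound 3 to compound 4 (0.10 log units; within the scatter) in this assay, so on the 4-chlorophenyl core the added aromatic ring leaves no shift that can be read. Chloro in place of methoxy carries over to the naphthalen-2-yl core, with a 14-fold lower number from compound 2 to compound 4 (1.14 log units; beyond the scatter). The naphthalen-2-yl change cannot be told apart between the two cores: the same change on two cores in this assay, a 2.4-fold higher number (0.38 log units; beyond the scatter) from compound 1 to compound 2 and a 1.3-fold higher number (0.10 log units; within the scatter) from compound 3 to compound 4, 1.9-fold (0.28 log units) apart, within the scatter of two such steps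

The compounds shown leave open how this position responds to a group other than a carbon-only aromatic ring, such as an amine or a carboxylic acid. They also leave open whether fluoro or bromo would match chloro on the aromatic carbon.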